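The source may report more compounds than this note shows. Statements on the series, on what has been measured and on what is new or still open speak of the compounds shown alone.

So far, two compounds sharing one core have been measured. Among the measured compounds shown here, in a functional assay on MCF7 cells (Homo sapiens) for antiproliferative activity, read by MTT assay, with a stated time of 72 h (on this read-out higher numbers stand for weaker inhibition and lower numbers for stronger inhibition), compound 1 `Nc1nc(N)c2cc(CSC(=S)N3CCN(c4ccc(F)cc4)CC3)ccc2n1` gives 1920 nM and compound 2 `Nc1nc(N)c2cc(CSC(=S)N3CCN(c4ccc(F)cc4F)CC3)ccc2n1` gives 3670 nM, which places compound 2 within the usual scatter of its only measured neighbour. Compound 3 `Nc1nc(N)c2cc(CSC(=S)N3CCN(c4ccc(C(F)(F)F)cc4)CC3)ccc2n1` has not yet been measured. It carries 4-(trifluoromethyl)phenyl in place of 2,4-difluorophenyl on an amine nitrogen in a ring. For the measured compounds named here, only one measured step bears on this change, and only loosely. That step, a 1.9-fold higher number from compound 1 to compound 2 (0.28 log units; within the scatter), puts fluoro in place of hydrogen on an aromatic carbon of the group being exchanged here. With so little evidence, no step beyond the scatter is expected in this assay. The estimated step is a 1.3-fold lower number from compound 2 to compound 3 (0.10 log units; within the scatter). For compound 3 the estimate is 2900 nM, with an expected range from 1200 nM to 7000 nM.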

Compound 3, half-maximal inhibitory concentration: 7400 nM
For compound 3 the middle estimate is 2.6-fold (0.41 log units) below the measured one; measured number outside the range, above it.
By their numbers in this assay, from the lowest: compounds 1, 2 and 3 (each within the scatter of the next, the first and the last beyond it).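

In this assay, among the compounds shown here, trifluoromethyl in place of fluoro on the phenyl ring carried by the amine nitrogen gives the only step so far beyond the scatter (a 3.9-fold higher number from compound 1 to compound 3 (0.59 log units; beyond the scatter)), which shows that the number can respond to a change on this ring. By contrast, 4-(trifluoromethyl)phenyl in place of 2,4-difluorophenyl stays within the scatter (a 2.0-fold higher number from compound 2 to compound 3 (0.30 log units; within the scatter)), so these two groups cannot be ranked against each other. Nothing measured here explains the larger step.

The compounds shown leave open how a methoxy group, a nitrile or an amine on this phenyl ring would compare with fluoro and trifluoromethyl. They also leave open whether a plain phenyl or a simple alkyl chain on the same nitrogen would keep the number near those of the fluorinated compounds.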